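Replacing 2-bromophenyl with 4-methylphenyl in compound 3

The source may report more compounds than this note shows. Statements on the series, on what has been measured and on what is new or still open speak of the compounds shown alone.

compound 1 `NC1=NC2(CCOCC2)N(OCCCOc2ccc(F)cc2)C(N)=N1` gives 3280 nM
compound 2 `NC1=NC2(CCOCC2)N(OCCCOc2ccccc2Br)C(N)=N1` gives 30 nM

Both compounds were tested in a functional assay on HCT-116 cells (Homo sapiens) for antiproliferative activity, read by MTT assay, with a stated time of 72 h (on this read-out higher numbers stand for weaker inhibition and lower numbers for stronger inhibition), and share the same core. Compound 2 holds the lower of the two numbers, so it is the stronger inhibitor of this pair. Among the measured compounds shown here, the next compound, compound 3 `Cc1ccc(OCCCON2C(N)=NC(N)=NC23CCOCC3)cc1`, has no measurement yet. Its change is 4-methylphenyl in place of 2-bromophenyl on an oxygen on a saturated carbon with 4-methylphenyl in place of 2-bromophenyl on an oxygen on a saturated carbon. For the measured compounds named here, only one measured step bears on this change. Going the other way, a 110-fold lower number from compound 1 to compound 2 (2.04 log units; beyond the scatter) is a large step, well beyond the scatter, with 2-bromophenyl in place of 4-fluorophenyl. Of the two measured groups, 4-fluorophenyl is the closer match to 4-methylphenyl, so compound 3 is expected to lose much of what compound 2 gained. Going by the values given here, one step is thin evidence, and no measured compound carries a methyl group. A large move to a higher number is expected, meaning weaker inhibition, perhaps not as far as the number of compound 1. Compound 1 gives 3280 nM on this scale. The estimate means a 33-fold higher number from compound 2 to compound 3 (1.52 log units; beyond the scatter) as the expected step. The estimate for compound 3 is 1000 nM in this assay with an expected range of 150 nM to 5000 nM around it.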

Compound 3, half-maximal inhibitory concentration: 2390 nM
Beside the measured number, compound 3's estimate is 2.4-fold (0.38 log units) below it; the measured number falls inside the stated range.
By their numbers in this assay, from the lowest: compound 2; then compounds 3 and 1 (each within the scatter of the next).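

Putting 4-methylphenyl in place of 2-bromophenyl in this assay gives an 80-fold higher number from compound 2 to compound 3 (1.90 log units; beyond the scatter), so a substituted phenyl at this place on the oxygen is not enough by itself to keep the low number. The step with methyl in place of fluoro on an aromatic carbon is a 1.4-fold lower number from compound 1 to compound 3 (0.14 log units; within the scatter), which means these two groups cannot be told apart here, and the low number now stands out as belonging to the 2-bromophenyl compound alone among the three. No measurement shown explains why the 2-bromophenyl group differs so sharply from the other two groups.

Going by these compounds, what remains open is whether the low number depends on the bromine itself or on where the group sits on the ring, since the 2-bromophenyl group differs from the other two groups in both respects. A 4-bromophenyl group and a 2-methylphenyl group on the same chain and shared core would separate these two possibilities, and an unsubstituted phenyl group would give a baseline for all of them.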